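Swapping the amide for an ester on a shared core

The source may report more compounds than this note shows. Statements on the series, on what has been measured and on what is new or still open speak of the compounds shown alone.

Compound 1 `CNC(=O)/C=C/c1ccncc1-c1ccc2ccccc2c1`: 6620 nM
Compound 2 `CCOC(=O)/C=C/c1ccncc1-c1ccc2c(cnn2C)c1`: 5030 nM
Compound 3 `CCOC(=O)/C=C/c1ccncc1-c1ccc2[nH]ccc2c1`: 7440 nM

In a functional assay on A549 cells (Homo sapiens) for inhibition, read by sulforhodamine B assay, with a stated time of 72 h (on this read-out lower numbers stand for stronger inhibition of growth and higher numbers for weaker inhibition of growth), compound 1 gives 6620 nM, a value within the usual scatter of both other compounds, so the three cannot be separated on these numbers. Compound 4 `CCOC(=O)/C=C/c1ccncc1-c1ccc2ccccc2c1` has not yet been measured. It differs from compound 1 by ethoxy in place of methylamino on a carbonyl carbon. Among the measured compounds shown here, no measured pair isolates this change, so any expectation rests on indirect evidence. Compound 2 at 5030 nM and compound 3 at 7440 nM also carry the 2-(ethoxycarbonyl)ethenyl group, and neither stands apart from compound 1, although both differ from it elsewhere too. The expected step of a 1.1-fold lower number from compound 1 to compound 4 (0.06 log units; within the scatter) is therefore none beyond the scatter, with no firm direction. For compound 4 the estimated value is 5800 nM, with an expected range of 2800 nM to 12000 nM.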

Compound 4, concentration for 50% growth inhibition: 5380 nM
Beside the measured number, compound 4's estimate is 1.1-fold (0.03 log units) above it, within the range that was stated.
By their numbers in this assay, from the lowest: compounds 2, 4, 1 and 3 (each within the scatter of the next).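

Among the compounds shown here, compound 4 gives the first matched pair for this change, on the shared core of compound 1, where the earlier compounds differed in more than one place. In this assay the pair shows a 1.2-fold lower number from compound 1 to compound 4 (0.09 log units; within the scatter), so on this core, methylcarbamoyl and ethoxycarbonyl on the ethenyl chain cannot be told apart, even though the amide hydrogen leaves with the change. Nothing available accounts for how close the two compounds lie.

From the compounds shown here alone, it remains open whether a carboxylic acid or a longer chain such as propoxy on the same carbonyl carbon would move the number beyond the scatter. Going by these compounds, it is also open whether the exchange of methylamino and ethoxy would stay this small on the cores of compound 2 and compound 3.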